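Methylation of a phenol in a naphthoquinone amide series

The compounds below may be only part of what the source reports. "The series", "measured", "known", "first", "only" and "open" are said of these compounds alone.

Compound 1, `CC(C)(CNC(=O)c1ccc2ccccc2c1O)CC1=C(O)C(=O)c2ccccc2C1=O`: 26900 nM
Compound 2, `COc1c(C(=O)NCC(C)(C)CC2=C(O)C(=O)c3ccccc3C2=O)ccc2ccccc12`: 66900 nM
Compound 3, `COc1ccc(O)c(C(=O)NCC(C)(C)CC2=C(O)C(=O)c3ccccc3C2=O)c1`: "not active" (no number reported)

Compound 1 was tested in a functional assay on KB cells (Homo sapiens) for cytotoxicity, read by resazurin assay, with a stated time of 3 days (a lower number here means a stronger inhibitor, a higher number a weaker inhibitor), and gave 26900 nM. Compound 2 carries the change (methyl in place of hydrogen on an oxygen on an aromatic ring), and in this assay compound 2 gave 66900 nM; the step of a 2.5-fold higher number from compound 1 to compound 2 (0.40 log units; beyond the scatter) shows that capping the hydroxy group weakened the compound, though only modestly. Compound 3 is built on a different core, and the difference between the two cores is not broken down here. In this assay compound 3 is recorded as "not active" (no number reported), so no number is available for it.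

Compound 4, `COc1ccc(OC)c(C(=O)NCC(C)(C)CC2=C(O)C(=O)c3ccccc3C2=O)c1`, is the yet unmeasured partner of compound 3 and differs from it by methyl in place of hydrogen on an oxygen on an aromatic ring, the same change that turns compound 1 into compound 2, made at the same kind of place. Among the measured compounds shown here, in the only measured pair the change moved the number upward, as seen in a 2.5-fold higher number from compound 1 to compound 2 (0.40 log units; beyond the scatter). Since compound 3 already gave no measurable number, a change that weakened compound 1 is expected to leave compound 4 at best weak in this assay as well, and most likely the assay will again report no number. Compound 4 is therefore expected to give roughly 150000 nM, with a range of 60000 nM to 400000 nM, if a number is obtained at all.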

Compound 4, half-maximal inhibitory concentration: 86600 nM
For compound 4 the middle estimate is 1.7-fold (0.24 log units) above the measured one, within the range that was stated.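

In this assay compound 3 is recorded as "not active" (no number reported) and compound 4 gives 86600 nM so no step can be read between them. The compounds shown leave open how far replacing hydroxy with methoxy shifts the number on the 2-hydroxy-5-methoxyphenyl compound, and whether it moves in the same direction as in the naphthol pair. No supporting evidence bears on this result.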